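Compound 1 to compound 4: tert-butoxycarbonyl for pyridin-4-yl

The compounds below may be only part of what the source reports. "The series", "measured", "known", "first", "only" and "open" are said of these compounds alone.

Measured in an ADME assay on the whole organism (strain Sprague-Dawley) for metabolic stability, with Rattus norvegicus as the target, read by LC-MS; a lower number here means that the compound disappears faster, a higher number that the compound lasts longer:
- compound 1 `O=C1N(c2ccncc2)CCN1c1cccc2c1cnn2-c1ccccc1F` gives 1.3 h
- compound 2 `O=C1NCCN1CCOc1nn(-c2ccc(F)cc2F)c2ccc(F)cc12` gives 0.94 h
- compound 3 `O=C1NCCN1CCOc1nn(-c2ccc(F)cc2)c2ccc(F)cc12` gives 0.7 h

Compound 1 stands within the scatter of both compound 2 and compound 3, so the three values do not separate. The step to compound 4 `CC(C)(C)OC(=O)N1CCN(c2cccc3c2cnn3-c2ccccc2F)C1=O` places tert-butoxycarbonyl in place of pyridin-4-yl on an amide-type nitrogen in a ring.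

Within the data shown here, the only measured step between compounds that differ in one place is a 1.3-fold lower number from compound 2 to compound 3 (0.13 log units; within the scatter). It concerns an aromatic carbon, not this nitrogen, and it lies within the scatter, so it bears only weakly on the change. Among the measured compounds shown here, the data hold no measured step for this replacement. With compound 1 at 1.3 h as the anchor, no step beyond the scatter is expected in this assay, and no direction is favoured. The estimate means a 1.2-fold lower number from compound 1 to compound 4 (0.07 log units; within the scatter), an expected change that stays within the scatter. For compound 4 the estimated value is 1.1 h, with an expected range from 0.4 h to 2.8 h.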

Compound 4, half-life: 2 h
Beside the measured number, compound 4's estimate is 1.8-fold (0.26 log units) below it; low and high end bracket the measured number.
By their numbers in this assay, from the lowest: compounds 3, 2, 1 and 4 (each within the scatter of the next, the first and the last beyond it).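

In this assay, among these compounds, tert-butoxycarbonyl in place of pyridin-4-yl on the amide-type nitrogen in a ring gives a 1.5-fold higher number from compound 1 to compound 4 (0.19 log units; within the scatter), the first measured step at this nitrogen. The earlier compounds shown here held no step here; this one shows that the position takes a group with no ring in place of a six-membered aromatic ring with one hetero atom, and the half-life stays within the scatter. Nothing measured on these compounds accounts for this outcome.

Open, as far as these compounds go, is how a small group such as methyl or acetyl on this nitrogen would read in this assay. Also open, from the compounds shown here alone, is whether a piperidine ring, an amine or a carboxylic acid at this position would move the half-life beyond the scatter.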